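From Compound 1 to Compound 3: One Hydroxy Fewer

The source may hold more compounds than are shown below. What is called first, only, known or untested is meant among the compounds shown, and "the series" means these compounds.

Among the measured compounds shown here, in a functional assay on HCT-116 cells (Homo sapiens) for cytotoxicity, read by MTT assay, with a stated time of 72 h (a higher number here means a weaker inhibitor, a lower number a stronger inhibitor), compound 1 `O=C1c2c[n+]([O-])c3ccccc3c2C(=O)c2c1c1ccccc1n2Cc1cn([C@H]2O[C@H](CO)[C@@H](O)[C@H]2O)nn1` gives 710 nM and stands highest of the two numbers so far. Compound 2 `O=C1c2c[n+]([O-])c3ccccc3c2C(=O)c2c1c1ccccc1n2CCCCn1ccnc1` gives 240 nM in the same test, a gap beyond the usual scatter. Compound 3 `O=C1c2c[n+]([O-])c3ccccc3c2C(=O)c2c1c1ccccc1n2Cc1cn([C@@H]2C[C@H](O)[C@@H](CO)O2)nn1` differs from compound 1 by hydrogen in place of hydroxy on a saturated ring carbon and so carries hydrogen in place of hydroxy on a saturated ring carbon. The 3,4-dihydroxy-5-(hydroxymethyl)oxolan-2-yl group thereby becomes 4-hydroxy-5-(hydroxymethyl)oxolan-2-yl. For the measured compounds named here, no measured pair shows this change on its own. The expectation therefore starts from compound 1 at 710 nM and from the small size of the edit. No step beyond the scatter is expected in this assay here. The estimated move is a 1.2-fold lower number from compound 1 to compound 3 (0.07 log units; within the scatter) on this reading. Compound 3 is expected at 600 nM within a range of 250 nM to 1400 nM when tested.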

Compound 3, half-maximal inhibitory concentration: 50 nM
Beside the measured number, compound 3's estimate is 12-fold (1.08 log units) above it; the whole stated range lies above it.
By their numbers in this assay, from the lowest: compound 3; then compound 2; then compound 1.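

In this assay, among the compounds shown here, the record shows a 14-fold lower number from compound 1 to compound 3 (1.15 log units; beyond the scatter), so the single swap of hydroxy for hydrogen on this saturated ring carbon, two ring bonds from the ring oxygen, is a large step rather than a minor edit. For the compounds shown here, the earlier compounds offered no pair differing in one place, and this is the first evidence that the number responds strongly to what this one ring carbon carries. Nothing available accounts for the size of this step.

The compounds shown leave open how this carbon would respond to a group other than hydrogen or hydroxy, such as fluorine, methoxy or an amine. They also leave open whether removing the remaining hydroxy or the hydroxymethyl group of the 4-hydroxy-5-(hydroxymethyl)oxolan-2-yl group would move the number further in either direction.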